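Working notes: compound 3 ahead of its measurement

The source may hold more compounds than are shown below. What is called first, only, known or untested is meant among the compounds shown, and "the series" means these compounds.

Measured so far:
compound 1, `CO[C@@H]1C/C=C(\C)C(=O)N(C)[C@@H](C(C)C)C(=O)N[C@H](Cc2ccccc2)C(=O)N[C@@H](C(C)C)C(=O)O[C@H](c2ccccc2)[C@H](C)/C=C/C=C/1C`, gives > 100 nM, a limit rather than a number.
compound 2, `CO[C@@H]1C/C=C(\C)C(=O)N(C)[C@@H](C(C)C)C(=O)N[C@H](Cc2cc(Cl)c(O)c(Cl)c2)C(=O)N[C@@H](C(C)C)C(=O)O[C@H](c2ccccc2)[C@H](C)/C=C/C=C/1C`, gives 42.1 nM.

For the measured compounds named here, in a functional assay on HCT-116 cells (Homo sapiens) for antiproliferative activity, read by MTT assay, with a stated time of 72 h (on this read-out lower numbers stand for stronger inhibition and higher numbers for weaker inhibition), compound 2 holds the only number; the other entry is a limit, as the limit of > 100 nM in this assay, at which 1 of the 2 values shown sits, records. Going by the values given here, the single measured step, an at least 2.3-fold lower number from compound 1 to compound 2 (0.37 log units; beyond the scatter), concerns the aryl group and does not touch the position changed here.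

Compound 3, `CO[C@@H]1C/C=C(\C)C(=O)N(C)[C@@H](C(C)C)C(=O)N[C@H](Cc2cc(Cl)c(O)c(Cl)c2)C(=O)N[C@@H](CC(C)C)C(=O)O[C@H](c2ccccc2)[C@H](C)/C=C/C=C/1C`, differs from compound 2 by isobutyl in place of isopropyl on a saturated ring carbon. Among the compounds with values here, no measured step bears on an isopropyl-to-isobutyl exchange, so no change beyond the scatter is expected in this assay. Compound 3 is therefore estimated at 45 nM, between 15 nM and 130 nM, an expected step of a 1.1-fold higher number from compound 2 to compound 3 (0.03 log units; within the scatter).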

Compound 3, half-maximal inhibitory concentration: > 100 nM
Compound 3: only a limit was reported; the forecaster's own chance of this, stated with the estimate: 15%; middle value at least 2.2-fold (0.34 log units) from the limit.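

In this assay, isobutyl in place of isopropyl gives an at least 2.3-fold higher number from compound 2 to compound 3 (0.37 log units; beyond the scatter), so this saturated ring carbon next to the ring nitrogen is sensitive to the exchange, which the earlier aryl step could not show. Compound 3 gives > 100 nM, a limit and not a number. The 3,5-dichloro-4-hydroxybenzyl group therefore does not keep a measured value here once isobutyl enters.

On these data alone, how far the step really extends stays open: the limit of > 100 nM in this assay, at which 2 of the 3 values shown sit. Whether an ethyl group, a longer chain or an amine on this carbon would be accepted also remains open.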